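An Aryl Swap on a Triazole in a Flat Series

The source may hold more compounds than are shown below. What is called first, only, known or untested is meant among the compounds shown, and "the series" means these compounds.

Three compounds share one core and differ only in the aryl group on a nitrogen of their triazole. Compound 1 `Cc1cccc(-n2nncc2CN2C(=O)C3(C(C#N)=C(N)Oc4c(N)cc5nc6ccccc6nc5c43)c3ccccc32)c1` carries a 3-methylphenyl, compound 2 `COc1ccccc1-n1nncc1CN1C(=O)C2(C(C#N)=C(N)Oc3c(N)cc4nc5ccccc5nc4c32)c2ccccc21` a 2-methoxyphenyl, and compound 3 `Cc1ccc(-n2nncc2CN2C(=O)C3(C(C#N)=C(N)Oc4c(N)cc5nc6ccccc6nc5c43)c3ccccc32)cc1C` a 3,4-dimethylphenyl. In a functional assay on HCT-116 cells (Homo sapiens) for antiproliferative activity, read by MTT assay, with a stated time of 48 h (on this read-out lower numbers stand for stronger inhibition and higher numbers for weaker inhibition), compound 1 gives only the limit > 50000 nM, not a number. In this assay compound 2 likewise gives only the limit > 50000 nM. In this assay compound 3 too gives only the limit > 50000 nM. The three steps, a step that the two limits leave unreadable from compound 1 to compound 2, a step that the two limits leave unreadable from compound 1 to compound 3 and a step that the two limits leave unreadable from compound 2 to compound 3, therefore cannot be sized, since every value sits at the limit of > 50000 nM in this assay, at which 3 of the 3 values shown sit. Compound 3 thus stands at the same limit as the other two. Compound 4 `CCc1cccc(C)c1-n1nncc1CN1C(=O)C2(C(C#N)=C(N)Oc3c(N)cc4nc5ccccc5nc4c32)c2ccccc21` differs from compound 3 by 2-ethyl-6-methylphenyl in place of 3,4-dimethylphenyl on an aromatic nitrogen. Every aryl variation seen so far left the read-out at the limit, so the author expects the step that the limit leaves unreadable from compound 3 to compound 4 to be unreadable as well, with compound 4 most likely again reported only as a limit. The author's estimate for compound 4 in this assay is 60000 nM, within a range from 20000 nM to 200000 nM.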

Compound 4, half-maximal inhibitory concentration: > 50000 nM
Compound 4 was reported as a limit (the forecaster's own chance of this, stated with the estimate: 85%); the middle value lies beyond the limit too.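

In this assay, for the compounds shown here, compound 4 also gives only a limit, so no step between compound 4 and compound 1, compound 2 or compound 3 can be read: the limit of > 50000 nM in this assay, at which 4 of the 4 values shown sit. The compounds shown leave open how these four aryl groups rank beyond that limit.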